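The compounds below may be only part of what the source reports. "The series", "measured", "known", "first", "only" and "open" are said of these compounds alone.

Measured compounds:
Compound 1, `CO[C@H](C)[C@H](N)CN(C(=O)[C@@H]1C[C@H]1c1ccccc1)c1ccc(-c2ccccc2)cc1`, gives 0.68 nM in a functional assay for agonist activity at G protein-coupled receptor 88 (Homo sapiens), read by HTRF and cAMP accumulation; on this read-out lower numbers stand for an effect already at smaller amounts and higher numbers for an effect only at larger amounts of compound.
Compound 2, `CC[C@H](C)[C@H](N)CN(C(=O)[C@@H]1C[C@H]1c1cc(F)ccc1F)c1ccc(-c2ccccc2)cc1`, gives 770 nM in this assay.
Compound 3, `CC(C)C[C@H](N)CN(C(=O)[C@@H]1C[C@H]1c1ccccc1)c1ccc(-c2ccoc2)cc1`, gives 2000 nM in this assay.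

Among these three, compound 3 stands at the highest number in this assay; its nearest neighbour is compound 2, whose number is lower by a margin beyond the scatter, and compound 1 lies far lower still. Compound 4, `CC(C)C[C@H](N)CN(C(=O)[C@@H]1C[C@H]1c1ccccc1)c1ccc(-c2cccc(F)c2)cc1`, has not yet been measured in this assay. It differs from compound 3 in one place: 3-fluorophenyl in place of furan-3-yl on an aromatic carbon. Among the measured compounds shown here, no pair of measured compounds reports this change on its own, so its size is not known from a direct comparison. The two measured compounds that carry a six-membered aromatic ring of carbon only at this position, compound 1 with 0.68 nM and compound 2 with 770 nM, both show lower numbers than compound 3, though each also differs from compound 3 elsewhere. A step toward a lower number, beyond the scatter, is therefore expected, a 10-fold lower number from compound 3 to compound 4 (1.00 log units; beyond the scatter). Compound 4 is estimated at 200 nM, in a range from 30 nM to 1500 nM.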

Compound 4, half-maximal effective concentration: 2100 nM
Compound 4: middle estimate off by 11-fold (1.02 log units), on the low side; the whole stated range lies below it.
By their numbers in this assay, from the lowest: compound 1; then compound 2; then compounds 3 and 4 (each within the scatter of the next).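

In this assay, placing 3-fluorophenyl instead of furan-3-yl on this aromatic carbon, para to a large group, gives a 1.1-fold higher number from compound 3 to compound 4 (0.02 log units; within the scatter). This direct comparison shows that, on this core, the read-out does not separate the five-membered aromatic ring with one hetero atom from this six-membered aromatic ring of carbon only, so a ring of carbon only at this position does not by itself bring a lower number. No evidence at hand accounts for this result.

The compounds shown leave open whether plain phenyl on the core of compound 3 would give a number different from those of compound 3 and compound 4. They also leave open how a pyridyl ring, or a phenyl ring carrying an amine or a carboxylic acid, would read at this position.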